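Oxetane to Cyclopropylmethyl: Expected Cytotoxicity of Compound 3

A few compounds are considered here, and "the series" means these few. Any claim that something is new, unique, unknown or untested is made for them only; others in the source may bear on it.

Measured so far:
compound 1 `N#CCCCn1c(Cn2c(=O)n(C3CC3)c3ccncc32)cc2cc(Cl)ccc21` — in an ADME assay on HeLa cells (Homo sapiens) for cytotoxicity, read by ATP content, with a stated time of 3 days (on this read-out higher numbers stand for lower toxicity in this test and lower numbers for higher toxicity in this test), compound 1 gives > 50000 nM, which is a limit of the assay rather than a number.
compound 2 `CS(=O)(=O)CCCn1c(Cn2c(=O)n(C3COC3)c3ccncc32)cc2cc(Cl)ccc21` — in this assay compound 2 gives > 50000 nM, again a limit rather than a number.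

For the measured compounds named here, both measured values sit at the same limit, so no step between measured compounds can be drawn from them (the limit of > 50000 nM in this assay, at which 2 of the 2 values shown sit). Compound 2 thus stands at that limit, alongside compound 1, with no number of its own. The unmeasured compound 3 `CS(=O)(=O)CCCn1c(Cn2c(=O)n(CC3CC3)c3ccncc32)cc2cc(Cl)ccc21` differs from compound 2 by cyclopropylmethyl in place of oxetan-3-yl on an aromatic nitrogen. Going by the values given here, because the only evidence is the limit of > 50000 nM in this assay, at which 2 of the 2 values shown sit, no size or direction of a step in this assay can be read from the measured pair. The expected step is therefore a number no higher from compound 2 to compound 3 (the limit leaves the size open), nothing beyond the scatter. Compound 3 is expected to give about 50000 nM, within 20000 nM to 100000 nM, most likely reported once more only as a limit.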

Compound 3, half-maximal cytotoxic concentration: > 50000 nM
Compound 3 ended at the assay's limit; the forecaster's own chance of this, stated with the estimate: 80%; the middle value sits exactly at the limit.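

Compound 2 and compound 3 each give a limit of the assay rather than a number, so no step can be read between them: the limit of > 50000 nM in this assay, at which 3 of the 3 values shown sit. In this assay the compounds shown leave open the actual half-maximal cytotoxic concentration of each, and whether cyclopropylmethyl in place of oxetan-3-yl changes it at all.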